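The source may hold more compounds than are shown below. What is called first, only, known or untested is meant among the compounds shown, and "the series" means these compounds.

Going by the values given here, compound 1 `Cc1ccc(NC(=O)Nc2cccc(CNc3ncnc4ccccc34)c2)cc1` is one of two compounds so far measured in a functional assay on A549 cells (Homo sapiens) for antiproliferative activity, read by MTT assay; on this read-out lower numbers stand for stronger inhibition and higher numbers for weaker inhibition. Compound 1 gives 24900 nM, the higher of the two numbers, and its only companion, compound 2 `O=C(Nc1ccc(F)cc1)Nc1cccc(CNc2ncnc3ccccc23)c1`, gives 21000 nM. Among the compounds with values here, the single recorded step, a 1.2-fold lower number from compound 1 to compound 2 (0.07 log units; within the scatter), puts a fluoro in place of methyl on an aromatic carbon, and the two values sit within the scatter of each other.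

Compound 3 `O=C(Nc1cccc(CNc2ncnc3ccccc23)c1)Nc1ccccc1Cl` has not yet been measured. It differs from compound 1 in that (2-chlorophenyl in place of 4-methylphenyl on an amide-type nitrogen), a change on an amide-type nitrogen whose other neighbour is a carbonyl carbon. Within the data shown here, no measured pair shows this exact change; the only step that bears on it, a 1.2-fold lower number from compound 1 to compound 2 (0.07 log units; within the scatter), exchanged one substituent on that aryl group and stayed within the scatter. On that basis the expected step is a 1.1-fold lower number from compound 1 to compound 3 (0.05 log units; within the scatter), which is to say none beyond the scatter. For compound 3 the estimate in this assay is 22000 nM, with a range from 8000 nM to 60000 nM.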

Compound 3, half-maximal inhibitory concentration: 18000 nM
Beside the measured number, compound 3's estimate is 1.2-fold (0.09 log units) above it; the measured number falls inside the stated range.
By their numbers in this assay, from the lowest: compounds 3, 2 and 1 (each within the scatter of the next).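

In this assay, the exchange on the amide-type nitrogen now replaces the whole aryl group, not just one substituent on it: 2-chlorophenyl in place of 4-methylphenyl gives a step that stays within the scatter (a 1.4-fold lower number from compound 1 to compound 3 (0.14 log units; within the scatter)). Going by these compounds alone, the same holds for 2-chlorophenyl in place of 4-fluorophenyl (a 1.2-fold lower number from compound 2 to compound 3 (0.07 log units; within the scatter)), so among compounds 1, 2 and 3 all three exchanges of this aryl group stay within the scatter, and none of the three compounds goes against that reading, where the earlier pair offered only a single step. Nothing measured on these compounds offers an explanation for this flat result.

From the compounds shown here alone, all three compounds carry a chloro, fluoro or methyl substituent on a phenyl ring at this position, so it remains open whether an aminophenyl or carboxyphenyl group, or a longer alkyl chain in place of the aryl group on that nitrogen, would give a step beyond the scatter. Going by these compounds, it also remains open whether a change elsewhere on the shared core would do so, since these three compounds differ only in this one place.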